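A few compounds are considered here, and "the series" means these few. Any claim that something is new, unique, unknown or untested is made for them only; others in the source may bear on it.

Measured so far:
compound 1 `COc1ccccc1NC(=S)NC(=O)Nc1ccc2c(c1)C(=O)C(=O)N2Cc1ccccc1` gives 2.38 in a physicochemical assay for lipophilicity, in phosphate buffer, measured as octanol-water partition; a lower number here means a more polar compound, a higher number a more lipophilic compound;
compound 2 `COc1cccc(NC(=S)NC(=O)Nc2ccc3c(c2)C(=O)C(=O)N3Cc2ccccc2)c1` gives 2.4;
compound 3 `COc1ccccc1NC(=S)NC(=O)Nc1ccc2c(c1)C(=O)C(=O)N2Cc1ccccc1Cl` gives 3.18.

Compound 1 and compound 2 differ in one place, (3-methoxyphenyl in place of 2-methoxyphenyl on an amide-type nitrogen), and the step of a number 0.02 log units higher from compound 1 to compound 2 (within the scatter) is within the scatter of this assay. Compound 3 differs from compound 1 by chloro in place of hydrogen on an aromatic carbon, and the step of a number 0.80 log units higher from compound 1 to compound 3 (beyond the scatter) is a modest rise beyond the scatter.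

Compound 4 `COc1cccc(NC(=S)NC(=O)Nc2ccc3c(c2)C(=O)C(=O)N3Cc2ccccc2Cl)c1` is not yet measured. Among the measured compounds shown here, it differs from compound 3 by 3-methoxyphenyl in place of 2-methoxyphenyl on an amide-type nitrogen, which is the same change as the one from compound 1 to compound 2, made at the same place on the same kind of nitrogen, but here on the core that carries the chloro group.

The expected step of a number 0.02 log units higher from compound 3 to compound 4 (within the scatter) rests on the earlier step of a number 0.02 log units higher from compound 1 to compound 2 (within the scatter), which was within the scatter, so compound 4 is expected to stay close to compound 3. The estimate for compound 4 is 3.2, between 2.9 and 3.5.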

Compound 4, partition coefficient: 3.19
For compound 4 the middle estimate is 0.01 log units above the measured one; measured number inside the range.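

In this assay replacing 2-methoxyphenyl with 3-methoxyphenyl on the chloro-bearing core gives a number 0.01 log units higher from compound 3 to compound 4 (within the scatter) and so again makes no change beyond the scatter, just as on the core of compound 1, while adding the chloro group to the 3-methoxyphenyl compound gives a number 0.79 log units higher from compound 2 to compound 4 (beyond the scatter) and so still produces a modest rise. This shows the change carrying over between these two cores in this one assay, but it rests on a single pair per core and does not show that it would carry over to any other core. Nothing available explains why the methoxy move leaves the number in place.

The compounds shown leave open whether the same holds when an amine, a carboxylic acid or a longer chain such as ethoxy stands in place of the methoxy group.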